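The source may hold more compounds than are shown below. What is called first, only, known or untested is meant among the compounds shown, and "the series" means these compounds.

Compound 1 `C#Cc1cccc(Nc2ncnc3oc(C)c(C(=O)OCC)c23)c1` gives > 1000000 nM in a functional assay on MCF7 cells (Homo sapiens) for cytotoxicity, read by MTT assay, with a stated time of 72 h; a higher number here means a weaker inhibitor, a lower number a stronger inhibitor.
Compound 2 `CCOC(=O)c1c(C)oc2ncnc(Nc3ccc(OCc4cccc(F)c4)c(Cl)c3)c12` gives 257000 nM in this assay.

The value of compound 1 is a limit of the assay rather than a number, and compound 1 sits at the limit of > 1000000 nM in this assay, at which 1 of the 2 values shown sits. Compound 2 alone gives a number. Among the compounds with values here, the two measured compounds differ in more than one place, and no step between them can be read. Compound 3 `CCOC(=O)c1c(C)oc2ncnc(Nc3ccccc3)c12` has not yet been measured. It differs from compound 1 in a single place: hydrogen in place of ethynyl on an aromatic carbon. With only a limit known for compound 1, the step to compound 3 has no measured change to lean on. The step of an at least 1.2-fold lower number from compound 1 to compound 3 (0.09 log units; that floor lies within the scatter) in this assay is expected to be none beyond the usual scatter, with compound 3 likely staying at or near the limit. Compound 3 is estimated at 800000 nM, within 150000 nM to 3000000 nM, and a limit is again a likely outcome.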

Compound 3, half-maximal inhibitory concentration: 851000 nM
For compound 3 the middle estimate is 1.1-fold (0.03 log units) below the measured one, within the range that was stated.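

Replacing the ethynyl group gives a plain phenyl at this place, and in this assay compound 3 gives a real number, 851000 nM. For compound 1, the value > 1000000 nM is a limit of the assay and not a number. The change therefore reads only as an at least 1.1-fold lower number from compound 1 to compound 3 (0.07 log units; that floor lies within the scatter), which is a floor rather than a full size, so ethynyl on this aromatic carbon shows no gain over hydrogen, and the true size of the step stays hidden because of where compound 1 stands: the limit of > 1000000 nM in this assay, at which 1 of the 3 values shown sits.

As far as these compounds go, whether an amine or a methoxy group on this aromatic carbon would move the number beyond the scatter remains open. Within the data shown here, no step to compound 2 can be read, since it differs from compound 1 and from compound 3 in more than one place.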